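The source may hold more compounds than are shown below. What is called first, only, known or untested is meant among the compounds shown, and "the series" means these compounds.

Measured so far in a functional assay on SK-BR-3 cells (Homo sapiens) for antiproliferative activity, read by MTT assay, with a stated time of 72 h; a higher number here means a weaker inhibitor, a lower number a stronger inhibitor:
- compound 1 `CCN1CCN(c2cc(C)c3cc(NC(=O)c4cccc(C)c4)ccc3n2)CC1`: 13700 nM
- compound 2 `Cc1cc(N2CCN(C(C)C)CC2)nc2ccc(NC(=O)c3ccc(Cl)c(Cl)c3)cc12`: 6680 nM
- compound 3 `Cc1cc(NCCN2CCCCC2)nc2ccc(NC(=O)c3ccc(Cl)c(Cl)c3)cc12`: 1800 nM

Compound 1 gives the highest number of the three, with compound 2 next and compound 3 furthest away; the gap to each lies beyond the scatter. Among the measured compounds shown here, the only single-site step in the set, a 3.7-fold lower number from compound 2 to compound 3 (0.57 log units; beyond the scatter), concerns the amine-bearing side of the shared core and says nothing about the amide side.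

For the measured compounds named here, compound 4 `CCN1CCN(c2cc(C)c3cc(NC(=O)c4ccco4)ccc3n2)CC1` is the one change on the amide side: furan-2-yl in place of 3-methylphenyl on a carbonyl carbon. Going by the values given here, no measured pair touches this position, so there is no step to lean on, and nothing in the set supports an expectation of a change beyond the scatter in either direction. The working expectation is therefore a 1.0-fold higher number from compound 1 to compound 4 (0.01 log units; within the scatter), a number close to that of compound 1.

Compound 4 is estimated at 14000 nM, with a range from 5000 nM to 40000 nM, wide for lack of any bearing step.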

Compound 4, half-maximal inhibitory concentration: 37500 nM
For compound 4 the middle estimate is 2.7-fold (0.43 log units) below the measured one; low and high end bracket the measured number.
By their numbers in this assay, from the lowest: compound 3; then compound 2; then compound 1; then compound 4.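

In this assay, among the compounds shown here, the amide side of the shared core is not silent: a 2.7-fold higher number from compound 1 to compound 4 (0.44 log units; beyond the scatter) is the first step read at this position, and it lies beyond the scatter. On a carbonyl carbon whose other neighbour is the amide-type nitrogen, a five-membered aromatic ring with one hetero atom therefore gives a weaker result than 3-methylphenyl, at least with the 4-ethylpiperazin-1-yl side of compound 1 held fixed. Nothing measured here bears on what lies behind this step.

Open, on these data alone, is whether the step follows from the change of ring or from the loss of the methyl group, a question an unsubstituted phenyl on the same carbonyl carbon could address. Also open, as far as these compounds go, is whether furan-2-yl carries the same step when the amine side is (2-(piperidin-1-yl)ethyl)amino.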